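Moving the Methyl on the Pyridine of Compound 1

The compounds below may be only part of what the source reports. "The series", "measured", "known", "first", "only" and "open" are said of these compounds alone.

Compound 1 `Cc1cccc(/C(N)=N/NC(=S)N2CCN(c3ccccn3)CC2)n1` was tested in a functional assay on A-375 cells (Homo sapiens) for cytotoxicity, read by MTT assay, with a stated time of 72 h, tested at 10 uM (on this read-out higher numbers stand for more inhibition of growth at the one concentration tested and lower numbers for less inhibition of growth), and gives 63.3%. Among the three compounds measured, compound 1 stands lowest. Compound 3 `Cc1ccnc(/C(N)=N/NC(=S)N2CCOCC2)c1` gives 86% in this assay, and compound 2 `N/C(=N\NC(=S)N1CCCCCC1)c1ccccn1` gives 86.5%; both lie beyond the scatter above compound 1. Compound 4 `Cc1ccnc(/C(N)=N/NC(=S)N2CCN(c3ccccn3)CC2)c1` has not yet been measured. It differs from compound 1 in one place: 4-methylpyridin-2-yl in place of 6-methylpyridin-2-yl on a carbon with a double bond to nitrogen. Within the data shown here, no measured pair shows this change alone. A modest rise is expected because compound 3 gives 86% while carrying the same 4-methylpyridin-2-yl, though with a different amine on the other end. The expected step is a number 8.7 percentage points higher from compound 1 to compound 4 (within the scatter), upward but within the scatter. Compound 4 is estimated at 72%, with a range from 52% to 90%.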

Compound 4, percent growth inhibition at one concentration: 76%
Beside the measured number, compound 4's estimate is 4 percentage points below it; the measured number falls inside the stated range.
By their numbers in this assay, from the lowest: compound 1; then compounds 4, 3 and 2 (each within the scatter of the next, the first and the last beyond it).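

With the rest of the molecule unchanged, replacing 6-methylpyridin-2-yl with 4-methylpyridin-2-yl gives a number 12.7 percentage points higher from compound 1 to compound 4 (beyond the scatter). Among these compounds, this is the first direct comparison of the two groups, since the earlier compounds all differed in more than one place. It shows that growth inhibition at this single concentration depends on where the methyl sits on the ring, but nothing here explains why. On these data alone, whether the same shift gives a similar step with a different amine on the other end remains open. So does the effect of an ethyl or methoxy group in place of the methyl.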